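Cytotoxicity in MT2 cells: a lactam for a sulfone

The source may hold more compounds than are shown below. What is called first, only, known or untested is meant among the compounds shown, and "the series" means these compounds.

Compound 1 `COc1cc(F)ccc1CNC(=O)c1cc2nc(C)c([C@H](OC(C)(C)C)C(=O)O)c(-c3cc(F)c4c(c3C)CCCO4)n2n1` in an ADME assay on MT2 cells (Homo sapiens) for cytotoxicity (on this read-out lower numbers stand for higher toxicity in this test and higher numbers for lower toxicity in this test), gives > 40000 nM, a limit of the assay rather than a number. Compound 2 `Cc1nc2cc(C(=O)NCc3ccc(F)cc3O)nn2c(-c2cc(F)c3c(c2C)CCCO3)c1[C@H](OC(C)(C)C)C(=O)O` gives > 40000 nM in this assay, again a limit. Compound 3 `Cc1nc2cc(C(=O)NCc3ccc(F)cc3S(C)(=O)=O)nn2c(-c2cc(F)c3c(c2C)CCCO3)c1[C@H](OC(C)(C)C)C(=O)O` gives > 40000 nM in this assay, also a limit.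

All three measured compounds share one core and differ only in the substituent on the benzylamide ring. Among the measured compounds shown here, compound 3 therefore stands at the same place as the other two: at the limit of > 40000 nM in this assay, at which 3 of the 3 values shown sit, where every value so far sits. None of the three steps among them can be read, since both ends of each are limits: a step that the two limits leave unreadable from compound 1 to compound 2, a step that the two limits leave unreadable from compound 1 to compound 3 and a step that the two limits leave unreadable from compound 2 to compound 3.

Compound 4 `Cc1nc2cc(C(=O)NCc3ccc(F)cc3N3CCCC3=O)nn2c(-c2cc(F)c3c(c2C)CCCO3)c1[C@H](OC(C)(C)C)C(=O)O` has not yet been measured. It differs from compound 3 by 2-oxopyrrolidin-1-yl in place of methylsulfonyl on an aromatic carbon. The two steps that touch the methylsulfonyl group, from compound 1 and from compound 2 to compound 3, bear on this change, but their size is not readable. No step among these compounds shows a movement beyond the scatter of this assay, and nothing suggests a direction for the new substituent.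

On that basis compound 4 is expected to give 40000 nM in this assay, within 20000 nM to 80000 nM, most probably reported as a limit again. The step implied by this estimate is a number no higher from compound 3 to compound 4 (the limit leaves the size open), no change beyond the scatter.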

Compound 4, half-maximal cytotoxic concentration: > 40000 nM
Compound 4 ended at the assay's limit; the forecaster's own chance of this, stated with the estimate: 85%; the middle value lies on the limit itself.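

Compound 4 gives > 40000 nM in this assay, again a limit of the assay and not a number, so none of the steps joining it to compound 1, compound 2 and compound 3 can be read: the limit of > 40000 nM in this assay, at which 4 of the 4 values shown sit.

The compounds shown leave open whether these substituents on the benzylamide ring differ at all in this assay.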